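A large group replaces fluoro at the assay limit

A few compounds are considered here, and "the series" means these few. Any claim that something is new, unique, unknown or untested is made for them only; others in the source may bear on it.

Measured so far in an ADME assay on HepG2 cells (Homo sapiens) for cytotoxicity, read by luminescence, with a stated time of 72 h; a higher number here means that more compound is needed for the effect, a lower number that less compound is needed:
- Compound 1 `CCOC(=O)c1c(-c2cccc(F)c2)[nH]c2cc(OC)ccc2c1=O`: > 21500 nM
- Compound 2 `CCOC(=O)c1c(-c2cccc(F)c2)[nH]c2cc(OC)c(F)cc2c1=O`: > 21500 nM
- Compound 3 `CCOC(=O)c1c(-c2cc(F)cc(OC)c2)[nH]c2cc(OC)c(F)cc2c1=O`: > 21500 nM

Compound 2 stands at > 21500 nM, and this is a limit of the assay and not a number. The same holds for the other two compounds, so the series offers (the limit of > 21500 nM in this assay, at which 3 of the 3 values shown sit).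

Compound 4 `CCOC(=O)c1c(-c2cccc(Oc3c(C)cccc3C)c2)[nH]c2cc(OC)c(F)cc2c1=O` has not yet been measured. It follows from compound 2 by one structural change, (2,6-dimethylphenoxy in place of fluoro on an aromatic carbon). In words, 2,6-dimethylphenoxy takes the place of fluoro on an aromatic carbon.

Going by the values given here, two measured steps bear on this change. Among the compounds with values here, the first is a step that the two limits leave unreadable from compound 1 to compound 2, and the second is a step that the two limits leave unreadable from compound 2 to compound 3. The second is the closer guide, since it too alters the six-membered aromatic ring of carbon only, but neither step has a size that can be read. Neither step covers a group as large as the one entering here, so a lower value cannot be ruled out.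

No shift beyond the scatter is expected in this assay, and compound 4 may again report only a limit. The expected change is a step that the limit leaves unreadable from compound 2 to compound 4. For compound 4 the estimated value is 22000 nM, with an expected range from 8000 nM to 50000 nM.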

Compound 4, half-maximal effective concentration: > 21500 nM
Compound 4 ended at the assay's limit (the forecaster's own chance of this, stated with the estimate: 65%); the middle value is on the limit's open side.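

In this assay compound 4 gives > 21500 nM, which is a limit of the assay and not a number. Compound 2 also sits at a limit, so the step between compound 2 and compound 4 cannot be read. All the compounds shown share one reading: the limit of > 21500 nM in this assay, at which 4 of the 4 values shown sit.

The compounds shown leave open what size any of these structural changes has on the half-maximal effective concentration.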